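A few compounds are considered here, and "the series" means these few. Any claim that something is new, unique, unknown or untested is made for them only; others in the source may bear on it.

The three measured compounds share one core and differ only in the group on the aromatic carbon of the five-membered ring that holds one nitrogen and one sulfur. Compound 1 `COc1ccc(-c2csc(N/N=C(\C)c3cc4ccccc4o3)n2)cc1` carries 4-methoxyphenyl there and in a functional assay on HeLa cells (Homo sapiens) for antiproliferative activity (on this read-out lower numbers stand for stronger inhibition and higher numbers for weaker inhibition), compound 1 gives 18700 nM. Compound 2 `C/C(=N\Nc1nc(-c2ccccc2)cs1)c1cc2ccccc2o1` carries phenyl, and compound 2 gives 11700 nM. Compound 3 `CCOC(=O)Cc1csc(N/N=C(\C)c2cc3ccccc3o2)n1` carries (ethoxycarbonyl)methyl, and compound 3 gives 9260 nM, the smallest of the three numbers; the gap to compound 2 is within the scatter, whereas a 2.0-fold lower number from compound 1 to compound 3 (0.31 log units; beyond the scatter) lies beyond it. Compound 4 `C/C(=N\Nc1nc(-c2cc3ccccc3o2)cs1)c1cc2ccccc2o1` is the next step: 1-benzofuran-2-yl in place of (ethoxycarbonyl)methyl on an aromatic carbon. The measured steps that bear on this change run the other way, from an aromatic group to the (ethoxycarbonyl)methyl chain: a 1.3-fold lower number from compound 2 to compound 3 (0.10 log units; within the scatter) and a 2.0-fold lower number from compound 1 to compound 3 (0.31 log units; beyond the scatter). Putting an aromatic group back in place of that chain is therefore expected to move the number up in this assay by a small amount, if by anything beyond the scatter. Compound 4 is expected to give about 13000 nM, with a range from 6500 nM to 28000 nM. The expected step is a 1.4-fold higher number from compound 3 to compound 4 (0.15 log units; within the scatter), kept small because a 1.3-fold lower number from compound 2 to compound 3 (0.10 log units; within the scatter) itself stayed within the scatter.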

Compound 4, half-maximal inhibitory concentration: 24100 nM
Beside the measured number, compound 4's estimate is 1.9-fold (0.27 log units) below it; measured number inside the range.
By their numbers in this assay, from the lowest: compounds 3, 2, 1 and 4 (each within the scatter of the next, the first and the last beyond it).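

In this assay, 1-benzofuran-2-yl on this aromatic carbon, next to the ring nitrogen, gives the first change from the (ethoxycarbonyl)methyl chain to be tested in this direction, and the result is a clear step (a 2.6-fold higher number from compound 3 to compound 4 (0.42 log units; beyond the scatter)). The aromatic groups at this position also prove not to be interchangeable: the replacement of phenyl gives a step beyond the scatter (a 2.1-fold higher number from compound 2 to compound 4 (0.31 log units; beyond the scatter)), whereas the replacement of 4-methoxyphenyl gives one within it (a 1.3-fold higher number from compound 1 to compound 4 (0.11 log units; within the scatter)), so 1-benzofuran-2-yl and 4-methoxyphenyl cannot be told apart here. Nothing available accounts for these differences between the groups.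

The compounds shown leave open whether a carboxylic acid in place of the ethyl ester, a longer chain or an amine on this aromatic carbon would read differently from (ethoxycarbonyl)methyl. They also leave open whether the steps seen here would hold if the 1-benzofuran-2-yl group at the other end of the shared core were replaced by phenyl.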